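The source may report more compounds than this note shows. Statements on the series, on what has been measured and on what is new or still open speak of the compounds shown alone.

Among the measured compounds shown here, in an in vitro ADME assay on microsomes from liver (Rattus norvegicus) for metabolic stability, tested at 2 uM (a higher number here means that the compound lasts longer, a lower number that the compound disappears faster), compound 2 `CC(C)(C#Cc1ccc(NC(=O)CSc2nnnn2-c2ccc(C3CC3)cc2Cl)c(Cl)c1)NC(=O)CN` gives 1.82 h, the higher of the two numbers so far, while compound 1 `O=C(O)C#Cc1ccc(NC(=O)CSc2nnnn2-c2ccc(C3CC3)cc2Cl)c(Cl)c1` gives 0.333 h. For the measured compounds named here, the one measured step, a 5.5-fold higher number from compound 1 to compound 2 (0.74 log units; beyond the scatter), is modest and beyond the scatter. Compound 3 `CC(C)(C#Cc1ccc(NC(=O)CSc2nnnn2-c2ccc(C3CC3)cc2Cl)c(Cl)c1)CNCC(=O)O` differs from compound 2 as follows: ((carboxymethyl)amino)methyl in place of ((aminomethyl)carbonyl)amino on a saturated chain carbon bound to two saturated chain carbons and a triple-bonded carbon. The measured step bears only loosely, since it replaced carboxy itself. Still, the entering group holds a carboxy, as does compound 1 at 0.333 h, so a downward move of part of that size is expected in this assay. The expected step is a 2.0-fold lower number from compound 2 to compound 3 (0.31 log units; beyond the scatter). For compound 3 the estimated half-life is 0.9 h, within a range of 0.3 h to 2.5 h.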

Compound 3, half-life: 1.32 h
Estimate against measurement, compound 3: 1.5-fold (0.17 log units) below; the measured number falls inside the stated range.
By their numbers in this assay, from the lowest: compound 1; then compounds 3 and 2 (each within the scatter of the next).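

In this assay, ((carboxymethyl)amino)methyl and ((aminomethyl)carbonyl)amino on this saturated chain carbon cannot be told apart, the step being a 1.4-fold lower number from compound 2 to compound 3 (0.14 log units; within the scatter). A carboxy carried at the end of the 1-(((carboxymethyl)amino)methyl)-1-methylethyl group does not go with the short half-life of compound 1, as shown by a 4.0-fold higher number from compound 1 to compound 3 (0.60 log units; beyond the scatter). No available evidence accounts for either step. Still open, from the compounds shown here alone, is whether a plain amine or a longer chain ending in a carboxylic acid on this same carbon would give a half-life in the same range.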